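Trifluoromethyl in Place of Hydrogen on Compound 2

The source may hold more compounds than are shown below. What is called first, only, known or untested is meant among the compounds shown, and "the series" means these compounds.

Compound 2 `C=C1C[C@]23C[C@@]1(O)CC[C@@H]2c1cccc(C)c1[C@@H]3Cn1cc(-c2ccccc2)nn1` gives only a limit in a functional assay on MCF7 cells (Homo sapiens) for cytotoxicity, read by MTT assay, with a stated time of 4 days; on this read-out lower numbers stand for stronger inhibition and higher numbers for weaker inhibition: it shows > 20000 nM, which is the edge of the assay and not a number. Compound 1 `Cc1ccc(S(=O)(=O)Oc2ccc3c(c2C)[C@H](Cn2cc(-c4ccc(C(F)(F)F)cc4)nn2)[C@@]24CC(=O)[C@@](C)(CC[C@@H]32)C4)cc1` also sits at a limit in this assay, with > 20000 nM. Going by the values given here, compound 3 `C=C1C(=O)[C@]23C[C@@]1(O)CC[C@H]2c1ccc(O)c(C)c1[C@@H]3Cn1cc(-c2ccc(C)cc2)nn1` is the one compound of the three with a measured number, reaching 370 nM in this assay, but it differs from compound 2 in more than one place, so no single step between measured compounds can be read from these three. Among the compounds with values here, the only evidence that bears on the matter is the limit of > 20000 nM in this assay, at which 2 of the 3 values shown sit. Compound 4 `C=C1C[C@]23C[C@@]1(O)CC[C@@H]2c1cccc(C)c1[C@@H]3Cn1cc(-c2ccc(C(F)(F)F)cc2)nn1` has not yet been measured. It differs from compound 2 by trifluoromethyl in place of hydrogen on an aromatic carbon. Compound 1 already carries 4-(trifluoromethyl)phenyl and still sits at its limit. Within the data shown here, with no step between measured compounds to rest on, the expected step that the limit leaves unreadable from compound 2 to compound 4 is none beyond the scatter. Compound 4 is therefore expected to give about 25000 nM in this assay, within a range of 5000 nM to 100000 nM, and most probably the assay will again report only a limit for it.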

Compound 4, half-maximal inhibitory concentration: > 20000 nM
Compound 4 was reported as a limit; the forecaster's own chance of this, stated with the estimate: 70%; the middle value is on the limit's open side.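

In this assay compound 4 gives > 20000 nM, which is a limit of the assay and not a number. Going by these compounds alone, compound 2 sits at the same limit, so no step between compound 2 and compound 4 can be read: the limit of > 20000 nM in this assay, at which 3 of the 4 values shown sit. The compounds shown leave open whether trifluoromethyl in place of hydrogen on an aromatic carbon changes activity in this assay at all.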